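This account rests on a few compounds, and the source may have more. Where it says the series, first, only, none or still open, it means among the compounds named here.

Working notes on the series. Compound 1 `COc1ccc(OCC(=O)Nc2cccc(NC(=O)c3ccc(N(C)C)cc3)c2)cc1F` gives 652 nM in an assay on isolated protein for inhibition of Rho-associated protein kinase 2 (Homo sapiens), read by scintillation counting, radiometric assay and 33P incorporation, with a stated time of 40 min, in the presence of a further agent that is not named here; a lower number here means a stronger inhibitor, a higher number a weaker inhibitor. Among the measured compounds shown here, compound 2 `CN(C)c1ccc(C(=O)Nc2cccc(NC(=O)COc3ccc4c(c3)OCCC4=O)c2)cc1` gives 85 nM in this assay, and the one step between measured compounds, a 7.7-fold lower number from compound 1 to compound 2 (0.88 log units; beyond the scatter), changes only the group on an oxygen on a saturated carbon. For the measured compounds named here, compound 3 `CCc1ccc(C(=O)Nc2cccc(NC(=O)COc3ccc4c(=O)ccoc4c3)c2)cc1` gives 24 nM in this assay, the lowest of the three numbers measured so far; compound 2 stands nearest with a higher number, compound 1 furthest, and both gaps lie beyond the scatter. Compound 4 `Cn1ccc(S(=O)(=O)Nc2cccc(NC(=O)COc3ccc4c(=O)ccoc4c3)c2)n1` keeps the side of compound 3 that carries the oxygen on a saturated carbon and differs at the other end of the shared core: a group of 9 heavy atoms (4 carbon, 2 nitrogen, 2 oxygen, 1 sulfur; one five-membered aromatic ring with 2 hetero atoms) in place of a group of 10 heavy atoms (9 carbon, 1 oxygen; one six-membered aromatic ring of carbon only), on a nitrogen on an aromatic ring. Going by the values given here, no measured step touches this nitrogen on an aromatic ring; the only step measured sits at the opposite end of the shared core, so it gives no precedent for size or direction in this assay here. The expectation is accordingly wide, with a modest rise in the number as the middle case: compound 4 is estimated at 150 nM, within a range from 30 nM to 800 nM. The expected step is a 6.3-fold higher number from compound 3 to compound 4 (0.80 log units; beyond the scatter).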

Compound 4, half-maximal inhibitory concentration: 1350 nM
Compound 4: middle estimate off by 9.0-fold (0.95 log units), on the low side; measured number outside the range, above it.
By their numbers in this assay, from the lowest: compound 3; then compound 2; then compound 1; then compound 4.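

In this assay, among the compounds shown here, the first measured change on the nitrogen on an aromatic ring gives a 56-fold higher number from compound 3 to compound 4 (1.75 log units; beyond the scatter), which shows that this end of the shared core is far from indifferent to what it carries, at least with the side bearing the oxygen on a saturated carbon held as in compound 3. This step also exceeds a 7.7-fold lower number from compound 1 to compound 2 (0.88 log units; beyond the scatter) at the opposite end, though it replaces the ring and the link to the nitrogen together, so it cannot assign the loss to either one. Nothing available offers an explanation for the size of this step.

Still open, as far as these compounds go, is whether the loss follows the sulfur-bearing link or the five-membered aromatic ring. A (4-ethylphenyl)sulfonyl group on this nitrogen would separate the two, and a simple acetyl group would show how much of the (4-ethylphenyl)carbonyl group's ring this position needs.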